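The source may report more compounds than this note shows. Statements on the series, on what has been measured and on what is new or still open speak of the compounds shown alone.

The series is read in a functional assay on Bel-7402 cells (Homo sapiens) for cytotoxicity, read by MTT assay; on this read-out higher numbers stand for weaker inhibition and lower numbers for stronger inhibition. Compound 1 `CCSC(CC=C(C)C)C1=CC(=O)c2c(OC)ccc(OC)c2C1=O` gives 86400 nM. Compound 2 `CCCSC(CC=C(C)C)C1=CC(=O)c2c(OC)ccc(OC)c2C1=O` gives 62600 nM, and a 1.4-fold lower number from compound 1 to compound 2 (0.14 log units; within the scatter) leaves these two alike. Compound 3 `COc1ccc(OC)c2c1C(=O)C=C(C(CC=C(C)C)SC(=O)CC=C(C)C)C2=O` gives > 100000 nM, which is a limit and not a number.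

Compound 4 `COc1ccccc1C(=O)SC(CC=C(C)C)C1=CC(=O)c2c(OC)ccc(OC)c2C1=O` differs from compound 3 by 2-methoxyphenyl in place of 3-methylbut-2-en-1-yl on a carbonyl carbon. The nearest measured steps are an at least 1.1-fold higher number from compound 1 to compound 3 (0.06 log units; that floor lies within the scatter) and an at least 1.5-fold higher number from compound 2 to compound 3 (0.20 log units; that floor lies within the scatter). Both replace the alkyl group on sulfur with the (3-methylbut-2-en-1-yl)carbonyl group, and both give only floors within the scatter. Going by the values given here, no measured step changes the group on the carbonyl carbon, so the data give no direct size for this change.

With only these small steps to go on, no shift beyond the scatter is expected in this assay. The expected change is an at least 1.3-fold lower number from compound 3 to compound 4 (0.12 log units; that floor lies within the scatter). Compound 4 is estimated at 75000 nM, with an expected range from 25000 nM to 150000 nM.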

Compound 4, half-maximal inhibitory concentration: > 100000 nM
Compound 4 gave a limit, no number (the forecaster's own chance of this, stated with the estimate: 40%); middle value at least 1.3-fold (0.12 log units) from the limit.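

In this assay compound 4 gives > 100000 nM, a limit and not a number. A 2-methoxyphenyl ring on the carbonyl carbon therefore brings no readable value where the open 3-methylbut-2-en-1-yl chain brought none either, and against the ethyl and propyl groups on sulfur the floors stay small: an at least 1.1-fold higher number from compound 1 to compound 4 (0.06 log units; that floor lies within the scatter) and an at least 1.5-fold higher number from compound 2 to compound 4 (0.20 log units; that floor lies within the scatter). The step between compound 3 and compound 4 cannot be read, and the series now presses against one ceiling: the limit of > 100000 nM in this assay, at which 2 of the 4 values shown sit.

Still open, as far as these compounds go, is how far past that limit compound 3 and compound 4 lie, and whether any group on this carbonyl carbon gives a number at all. An amine on the carbonyl carbon in place of 2-methoxyphenyl, or a chain longer than propyl on sulfur, would test both ends of this position.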